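A few compounds are considered here, and "the series" means these few. Any claim that something is new, unique, unknown or untested is made for them only; others in the source may bear on it.

Measured so far:
- compound 1 `N#CCC(=O)OCCc1c(-c2ccccc2Cl)c2cc(Cl)ccc2[nH]c1=O`: 100000 nM
- compound 2 `CC12CCC(C(=O)OCCc3c(-c4ccccc4Cl)c4cc(Cl)ccc4[nH]c3=O)(OC1=O)C2(C)C`: > 1800000 nM, a limit of the assay and not a number
- compound 3 `O=C(OCCc1c(-c2ccccc2Cl)c2cc(Cl)ccc2[nH]c1=O)c1ccc([N+](=O)[O-])cc1`: 1600000 nM

Of the two true numbers in an ADME assay on HepG2 2.2.15 cells (Homo sapiens) for cytotoxicity (on this read-out higher numbers stand for lower toxicity in this test and lower numbers for higher toxicity in this test), compound 3 holds the higher, 1600000 nM, against compound 1 at 100000 nM. The next step leads to compound 4 `O=C(OCCc1c(-c2ccccc2Cl)c2cc(Cl)ccc2[nH]c1=O)c1ccco1`, which has not been measured. It puts furan-2-yl in place of 4-nitrophenyl on a carbonyl carbon.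

The measured steps all change the group at this same place. Two of them are large, a 16-fold higher number from compound 1 to compound 3 (1.20 log units; beyond the scatter) and an at least 18-fold higher number from compound 1 to compound 2 (1.25 log units; beyond the scatter), and both leave the cyanomethyl group of compound 1 for a group that carries a ring. Between the two ring-bearing groups there is an at least 1.1-fold lower number from compound 2 to compound 3 (0.05 log units; that floor lies within the scatter), with a floor inside the scatter. Furan-2-yl also carries a ring, but it is smaller than 4-nitrophenyl, and no measured compound contains it. On these three compounds alone, compound 4 is expected to stay much closer to compound 3 than to compound 1, with a modest downward move that may not clear the scatter. The expected change is an estimated 2.0-fold lower number from compound 3 to compound 4 (0.30 log units; within the scatter). For compound 4 the estimated value is 800000 nM, with an expected range from 250000 nM to 2000000 nM.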

Compound 4, half-maximal cytotoxic concentration: 98000 nM
Estimate against measurement, compound 4: 8.2-fold (0.91 log units) above, and the stated range ends above it.
By their numbers in this assay, from the lowest: compounds 4 and 1 (each within the scatter of the next); then compound 3. At a limit, above all of these: compound 2.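

In this assay, compound 4 shows that a ring on this carbonyl carbon does not by itself keep the number high, which is the pattern compounds 1, 2 and 3 had suggested: a 16-fold lower number from compound 3 to compound 4 (1.21 log units; beyond the scatter), and compound 4 goes against that pattern. The ring-bearing furan-2-yl group instead places compound 4 with the ring-free cyanomethyl compound, a 1.0-fold lower number from compound 1 to compound 4 (0.01 log units; within the scatter), so at this place the two groups cannot be told apart by this read-out. Compound 2 has a limit of the assay and not a number, so its step, an at least 18-fold lower number from compound 2 to compound 4 (1.26 log units; beyond the scatter), is only a floor, set by this limit: the limit of > 1800000 nM in this assay, at which 1 of the 4 values shown sits.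

The exchange of 4-nitrophenyl for furan-2-yl alters the ring size, the ring atoms and the nitro group in one step, so the compounds shown do not say which of these differences goes with the large drop. Going by these compounds, an unsubstituted phenyl or a thiophen-2-yl on the same carbonyl carbon would divide these differences, and what an amine or a carboxylic acid on the ring would do at this place also remains open.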